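Phenyl in place of pyridin-4-yl on a triazole core

This account rests on a few compounds, and the source may have more. Where it says the series, first, only, none or still open, it means among the compounds named here.

Measured so far in an ADME assay on Vero cells (Chlorocebus sabaeus) for cytotoxicity, read by MTT assay, with a stated time of 72 h; on this read-out higher numbers stand for lower toxicity in this test and lower numbers for higher toxicity in this test:

compound 1 `OC(c1nnc(-c2ccccc2)[nH]1)C1CC=CCC1`: 358 ug/mL
compound 2 `OC(c1nnc(-c2ccncc2)[nH]1)C1CC=CCC1`: 388 ug/mL
compound 3 `CC1CCC(O)(c2nnc(-c3ccncc3)[nH]2)CC1`: 403 ug/mL

All three numbers lie close together. Within the data shown here, compound 1 and compound 2 share one core; the one change between them is phenyl in place of pyridin-4-yl on an aromatic carbon, and this gave a 1.1-fold lower number from compound 2 to compound 1 (0.03 log units; within the scatter). Compound 3 carries a different core, and the difference between the two cores is not broken down here; its value and that of compound 2 simply sit side by side, as do those of compound 3 and compound 1.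

The compound still to be measured is compound 4 `CC1CCC(O)(c2nnc(-c3ccccc3)[nH]2)CC1`. Among the measured compounds shown here, it arises from compound 3 by phenyl in place of pyridin-4-yl on an aromatic carbon, which is the same change, at the same place, as the one made from compound 2 to compound 1. For the measured compounds named here, the only guide to its effect is that single earlier step, where the aryl swap on the first core left this assay essentially unmoved.

On that basis the step from compound 3 to compound 4 is expected to be small, a 1.1-fold lower number from compound 3 to compound 4 (0.04 log units; within the scatter), because a 1.1-fold lower number from compound 2 to compound 1 (0.03 log units; within the scatter) was seen on the other core. Compound 4 is therefore estimated to give 370 ug/mL in this assay, with a plausible range from 240 ug/mL to 560 ug/mL.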

Compound 4, half-maximal cytotoxic concentration: 437 ug/mL
Compound 4: the middle estimate sits 1.2-fold (0.07 log units) below what was measured, within the range that was stated.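

In this assay, putting phenyl in place of pyridin-4-yl on the core of compound 3 gave a 1.1-fold higher number from compound 3 to compound 4 (0.04 log units; within the scatter), so this swap leaves the read-out within the usual scatter of repeated measurements. Set beside the earlier step on the other core, the change behaves alike on both cores, as far as this test can tell: the same change on two cores in this assay, a 1.1-fold lower number (0.03 log units; within the scatter) from compound 2 to compound 1 and a 1.1-fold higher number (0.04 log units; within the scatter) from compound 3 to compound 4, 1.2-fold (0.07 log units) apart, within the scatter of two such steps. This shows that, for these two pairs, the swap can be carried from one core to the other without a readable difference in this cytotoxicity test, but it does not show that the same would hold on a third core or in any other test, and it gives no reason why the swap makes so little difference.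

As far as these compounds go, only phenyl and pyridin-4-yl appear on this aromatic carbon, so it stays open whether a phenyl bearing an amine or a carboxylic acid would also leave the read-out in the same place. From the compounds shown here alone, it also stays open whether the same calm picture would hold if a longer chain stood in place of the group of 8 heavy atoms on the ring atom that bears it.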